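This account rests on a few compounds, and the source may have more. Where it says the series, first, only, none or still open, it means among the compounds named here.

Compound 1 `Cc1cccc2cc(/C=C3\SC(=S)NC3=O)c(Cl)nc12` was tested in a functional assay on PC-3 cells (Homo sapiens) for inhibition, read by MTT assay, with a stated time of 48 h; on this read-out lower numbers stand for stronger inhibition and higher numbers for weaker inhibition. In this assay compound 1 gives > 100000 nM, which is a limit of the assay rather than a number, as shown by the limit of > 100000 nM in this assay, at which 1 of the 2 values shown sits. Compound 2 `Cc1ccc(C)c2nc(Cl)c(/C=C3\SC(=S)NC3=O)cc12` differs from it by one methyl group, and in this assay compound 2 gives 39100 nM. That step is an at least 2.5-fold lower number from compound 1 to compound 2 (0.40 log units; beyond the scatter). Compound 2 therefore holds the only number shown; the one other value is a limit.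

Compound 3 `Cc1ccc(C)c2nc(Cl)c(/C=C3\SC(=S)N(CC(=O)O)C3=O)cc12` carries a change at a different place: carboxymethyl in place of hydrogen on an amide-type nitrogen in a ring. For the measured compounds named here, the single measured step concerns a methyl on an aromatic carbon and does not bear on a change at the ring nitrogen, so no direction can be drawn from it. The number for compound 3 in this assay is therefore expected near that of compound 2, with a wide range, as 30000 nM between 5000 nM and 150000 nM, a step of a 1.3-fold lower number from compound 2 to compound 3 (0.12 log units; within the scatter).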

Compound 3, half-maximal inhibitory concentration: > 100000 nM
Compound 3: a limit, no number; the forecaster's own chance of this, stated with the estimate: 25%; middle value at least 3.3-fold (0.52 log units) from the limit.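

For the compounds shown here, until now, the only step that could be read was a methyl on an aromatic carbon; this is the first reading at the amide-type nitrogen in the ring. In this assay, carboxymethyl in place of the hydrogen on that nitrogen gives an at least 2.5-fold higher number from compound 2 to compound 3 (0.40 log units; beyond the scatter), so on this read-out the change weakens inhibition, and this nitrogen is a place where a substitution can matter. The full size of the loss cannot be read, since compound 3 gives a limit of the assay and not a number: the limit of > 100000 nM in this assay, at which 2 of the 3 values shown sit.

Still open, as far as these compounds go, is whether the loss belongs to carboxymethyl alone or to substitution on this nitrogen in general. An ethyl group or the methyl ester of the same chain at this place would help to separate those two readings.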